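Benzofuran series: carboxymethoxy replacing chloro at the benzyl ring

The source may hold more compounds than are shown below. What is called first, only, known or untested is meant among the compounds shown, and "the series" means these compounds.

Three compounds of the shared core have numbers in a functional assay for inhibition of Polyunsaturated fatty acid 5-lipoxygenase (Homo sapiens), in the absence of a further agent; on this read-out lower numbers stand for stronger inhibition and higher numbers for weaker inhibition. Compound 1 `CCCc1cc(F)c2oc(Cc3ccc(OC)cc3)c(C)c2c1O` gives 7 nM, compound 2 `CCCc1cc(Cl)c2oc(Cc3ccc(OC)cc3)c(CCC)c2c1O` gives 20 nM, and compound 3 `CCCc1cc(Cl)c2oc(Cc3ccc(Cl)cc3)c(C)c2c1O` gives 26 nM. Compound 3 thus holds the highest of the three numbers; against compound 2 the gap is within the scatter, against compound 1 it lies beyond it.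

Compound 4 `CCCc1cc(Cl)c2oc(Cc3ccc(OCC(=O)O)cc3)c(C)c2c1O` differs from compound 3 in one place: carboxymethoxy in place of chloro on an aromatic carbon, on an aromatic carbon of a six-membered aromatic ring of carbon only, para to a large group. Among the compounds with values here, no measured pair shows this change, so no step is known for it. The step from compound 3 to compound 4 is expected to be modest and, if anything, towards weaker inhibition, as a 1.9-fold higher number from compound 3 to compound 4 (0.28 log units; within the scatter). For compound 4 a value of about 50 nM is estimated, expected to fall between 12 nM and 200 nM.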

Compound 4, half-maximal inhibitory concentration: 105 nM
Beside the measured number, compound 4's estimate is 2.1-fold (0.32 log units) below it, and the stated range covers the measured number.
By their numbers in this assay, from the lowest: compound 1; then compounds 2 and 3 (each within the scatter of the next); then compound 4.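

Within the data shown here, at this place, on an aromatic carbon of a six-membered aromatic ring of carbon only, para to a large group, the change from chloro to carboxymethoxy gives the first readable step in this assay: a 4.0-fold higher number from compound 3 to compound 4 (0.61 log units; beyond the scatter). The position therefore responds to this exchange with weaker inhibition, although compound 4 still gives 105 nM. Nothing measured here accounts for the size of this step.

Open, from the compounds shown here alone, is how a methyl ester, an amide or a longer chain ending in a carboxylic acid would behave at this place. Also open, going by these compounds, is whether the step would keep its size on the core of compound 1.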